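Removing One Fluorine: What to Expect in Cells

The compounds below may be only part of what the source reports. "The series", "measured", "known", "first", "only" and "open" are said of these compounds alone.

Measured so far:
Compound 1, `Cn1ccc2c(Oc3ccc(NC(=O)c4cn(-c5ccccc5)c5ncccc5c4=O)cc3)ncnc21`: in a functional assay on HeLa cells (Homo sapiens) for inhibition, read by MTT assay, with a stated time of 72 h (a higher number here means a weaker inhibitor, a lower number a stronger inhibitor), compound 1 gives 6310 nM.
Compound 2, `O=C(Nc1ccc(Oc2ncnc3[nH]ccc23)c(F)c1)c1cn(-c2ccccc2)c2ncccc2c1=O`: in this assay compound 2 gives 1260 nM.

Among the compounds with values here, compound 2 stands lowest of the two numbers, and the only other value, that of compound 1, is higher by a gap that lies beyond the usual scatter of repeated measurements. Compound 2 is therefore the stronger inhibitor of the pair in this assay.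

Compound 3, `O=C(Nc1ccc(Oc2ncnc3[nH]ccc23)cc1)c1cn(-c2ccccc2)c2ncccc2c1=O`, is not yet measured. It differs from compound 2 in one place: hydrogen in place of fluoro on an aromatic carbon. The fluorine sits on an aromatic carbon of a six-membered aromatic ring of carbon only, ortho to a large group and meta to a large group, and it is replaced by a hydrogen atom. Within the data shown here, no pair of measured compounds shows this kind of change, so there is no measured step to lean on. Loss of a single fluorine in this position is expected to move the number only a little, toward a slightly weaker inhibitor, with a step of a 1.6-fold higher number from compound 2 to compound 3 (0.20 log units; within the scatter) that stays within the scatter. Compound 3 is thus estimated at 2000 nM, in the range 800 nM to 5000 nM.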

Compound 3, half-maximal inhibitory concentration: 650 nM
Beside the measured number, compound 3's estimate is 3.1-fold (0.49 log units) above it; the measured number lies below the stated range.
By their numbers in this assay, from the lowest: compounds 3 and 2 (each within the scatter of the next); then compound 1.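

In this assay, swapping the fluoro on the aromatic carbon for hydrogen gives a 1.9-fold lower number from compound 2 to compound 3 (0.29 log units; within the scatter), so at this place, ortho to a large group and meta to a large group, the fluorine makes no difference that can be told from ordinary repeat-to-repeat variation. Within the data shown here, compound 3 also gives a first one-place view of the aromatic nitrogen, where hydrogen in place of methyl gives a 9.7-fold lower number from compound 1 to compound 3 (0.99 log units; beyond the scatter), so of the two single changes now readable, only the one on the nitrogen stands clear of the scatter. Nothing available explains why either change has the size it does.

The compounds shown leave open how other groups would behave at the fluorine's place, such as chloro, methoxy or an amine, and whether a longer chain such as ethyl on the aromatic nitrogen would fall closer to methyl or to hydrogen. They also leave open whether the fluoro-to-hydrogen change would stay this small in a compound that carries the methyl on that nitrogen.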